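A few compounds are considered here, and "the series" means these few. Any claim that something is new, unique, unknown or untested is made for them only; others in the source may bear on it.

Measured in a functional assay on DU-145 cells (Homo sapiens) for inhibition, read by trypan blue exclusion, with a stated time of 96 h; on this read-out lower numbers stand for stronger inhibition of growth and higher numbers for weaker inhibition of growth:
- Compound 1 `O=C(/C(=C\c1ccc([N+](=O)[O-])c(O)c1)SCc1ccc(Br)cc1)c1ccc(C(F)(F)F)cc1`: 1000 nM
- Compound 2 `O=C(/C(=C\c1ccc([N+](=O)[O-])c(O)c1)S(=O)(=O)c1ccc(Br)cc1)c1c(F)c(F)c(F)c(F)c1F`: 1000 nM
- Compound 3 `O=C(/C(=C\c1ccc([N+](=O)[O-])c(O)c1)SCc1ccc(Br)cc1)C1CCNC1`: > 100000 nM (a limit, not a number)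

Compound 3 stands at the limit of the numbers shown, (the limit of > 100000 nM in this assay, at which 1 of the 3 values shown sits). Compound 4 `O=C(/C(=C\c1ccc([N+](=O)[O-])c(O)c1)SCc1ccc(Br)cc1)c1c(F)c(F)c(F)c(F)c1F` differs from it in one place: 2,3,4,5,6-pentafluorophenyl in place of pyrrolidin-3-yl on a carbonyl carbon. In words, 2,3,4,5,6-pentafluorophenyl replaces pyrrolidin-3-yl on a carbonyl carbon.

Going by the values given here, one measured step bears directly on this change. It is an at least 100-fold higher number from compound 1 to compound 3 (2.00 log units; beyond the scatter), a large step that came with the arrival of pyrrolidin-3-yl in place of 4-(trifluoromethyl)phenyl. The present change runs the other way, returning an aromatic ring to the carbonyl carbon. Compound 2 also carries 2,3,4,5,6-pentafluorophenyl there, though it differs from compound 4 elsewhere, and compound 2 gives 1000 nM.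

A large move towards lower numbers is therefore expected in this assay, and the expected step is an at least 100-fold lower number from compound 3 to compound 4 (2.00 log units; beyond the scatter). The estimate for compound 4 is 1000 nM, with an expected range from 300 nM to 5000 nM.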

Compound 4, concentration for 50% growth inhibition: 10000 nM
Compound 4: middle estimate off by 10-fold (1.00 log units), on the low side; the whole stated range lies below it.
By their numbers in this assay, from the lowest: compounds 1 and 2 (each within the scatter of the next); then compound 4. At a limit, above all of these: compound 3.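

In this assay, an aromatic ring on the carbonyl carbon clearly separates from pyrrolidin-3-yl, as 2,3,4,5,6-pentafluorophenyl in place of pyrrolidin-3-yl gives an at least 10-fold lower number from compound 3 to compound 4 (1.00 log units; beyond the scatter). The earlier compounds shown here did not show that the choice of aromatic ring also counts at this position: 2,3,4,5,6-pentafluorophenyl in place of 4-(trifluoromethyl)phenyl gives a 10-fold higher number from compound 1 to compound 4 (1.00 log units; beyond the scatter). With 2,3,4,5,6-pentafluorophenyl held in place, the group on the double-bonded chain carbon counts as well, as (4-bromobenzyl)sulfanyl in place of (4-bromophenyl)sulfonyl gives a 10-fold higher number from compound 2 to compound 4 (1.00 log units; beyond the scatter).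

What separates the two aromatic rings cannot be told from these values. Going by these compounds, it remains open whether a plain phenyl, or a phenyl bearing an amine or a carboxylic acid, on this carbonyl carbon would fall nearer compound 1 or compound 4.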